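Ortho-Methyl Aniline Replaces Para-Iodo on the Sulfonamide

The source may report more compounds than this note shows. Statements on the series, on what has been measured and on what is new or still open speak of the compounds shown alone.

Three close relatives of one sulfonamide core have been tested in a functional assay on MCF7 cells (Homo sapiens) for antiproliferative activity, read by sulforhodamine B assay, with a stated time of 48 h; on this read-out higher numbers stand for weaker inhibition and lower numbers for stronger inhibition. Compound 2, `O=C1NCCN1c1ccc(S(=O)(=O)Nc2ccc(I)cc2)cc1`, gives 600 nM. Compound 1, `CCCCc1ccc(NS(=O)(=O)c2ccc(N3CCNC3=O)cc2)cc1`, gives 770 nM in this assay, and the change a 1.3-fold lower number from compound 1 to compound 2 (0.11 log units; within the scatter) is too small to separate the two. Compound 3, `CC(C)Cc1ccc(NS(=O)(=O)c2ccc(N3CCNC3=O)cc2)cc1`, reaches only a limit of the assay, > 1000 nM, so it carries no exact number. Against compound 2 this amounts to an at least 1.6-fold higher number from compound 2 to compound 3 (0.22 log units; that floor lies within the scatter), and against compound 1 to an at least 1.2-fold higher number from compound 1 to compound 3 (0.11 log units; that floor lies within the scatter), both resting on (the limit of > 1000 nM in this assay, at which 1 of the 3 values shown sits).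

The next compound, compound 4, `Cc1ccccc1NS(=O)(=O)c1ccc(N2CCNC2=O)cc1`, changes the ring on the sulfonamide nitrogen: 2-methylphenyl in place of 4-iodophenyl on a sulfonamide nitrogen. Within the data shown here, none of the measured steps swaps the whole aryl group, so the guidance is thin. The three measured partners all sit close together, with compound 3 beyond the limit, so a modest weakening is expected rather than a large shift. The step from compound 2 is estimated as a 2.5-fold higher number from compound 2 to compound 4 (0.40 log units; beyond the scatter), giving compound 4 an expected value of 1500 nM with a range from 400 nM to 6000 nM.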

Compound 4, half-maximal inhibitory concentration: 280 nM
Compound 4: middle estimate off by 5.4-fold (0.73 log units), on the high side; the measured number lies below the stated range.
By their numbers in this assay, from the lowest: compound 4; then compounds 2 and 1 (each within the scatter of the next). At a limit, above all of these: compound 3.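

In this assay, among these compounds, putting 2-methylphenyl in place of 4-iodophenyl on the sulfonamide nitrogen gives a 2.1-fold lower number from compound 2 to compound 4 (0.33 log units; beyond the scatter) and is the first step in this set to lie beyond the scatter. The aryl group at this position therefore does not need iodine to keep this activity, and both groups count 7 heavy atoms and one aromatic ring, so the number moved without a change in those counts. This single swap removes the iodine and adds the methyl group together, so the pair cannot separate the two changes, and nothing measured here gives a reason for the step.

As far as these compounds go, whether the methyl group is needed at all remains open, as a plain phenyl ring would test that. From the compounds shown here alone, how an amine or a carboxylic acid on this ring would read also remains unknown.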